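One Carbon Longer, Still at the Assay Limit

A few compounds are considered here, and "the series" means these few. Any claim that something is new, unique, unknown or untested is made for them only; others in the source may bear on it.

Compound 3, `O=C(CCCC(c1c[nH]c2ccccc12)c1c[nH]c2ccccc12)NO`, is measured in a functional assay on NCI-H460 cells (Homo sapiens) for cytotoxicity, read by sulforhodamine B assay, with a stated time of 24 h; on this read-out lower numbers stand for stronger inhibition and higher numbers for weaker inhibition. In this assay compound 3 gives only a limit, > 20000 nM. Its two neighbours tell the same story: compound 2, `O=C(CCC(c1c[nH]c2ccccc12)c1c[nH]c2ccccc12)NO`, is reported in this assay as a limit of > 20000 nM. Compound 1, `CN(O)C(=O)CCCCCC(c1c[nH]c2ccccc12)c1c[nH]c2ccccc12`, likewise stops at the limit > 20000 nM. All three values sit at the limit of > 20000 nM in this assay, at which 3 of the 3 values shown sit, so the steps among them cannot be sized: a step that the two limits leave unreadable from compound 1 to compound 2, a step that the two limits leave unreadable from compound 1 to compound 3 and a step that the two limits leave unreadable from compound 2 to compound 3 are each unreadable. Compound 4, `O=C(CCCCC(c1c[nH]c2ccccc12)c1c[nH]c2ccccc12)NO`, differs from compound 3 in one place: (hydroxycarbamoyl)methyl in place of hydroxycarbamoyl on a saturated chain carbon, four bonds along the chain from two aromatic carbons. The measured step that matches it most closely is a step that the two limits leave unreadable from compound 2 to compound 3, the same replacement made on a saturated chain carbon three bonds along the chain from two aromatic carbons, yet it offers no size to carry over. With no readable step anywhere in this set, the estimate for compound 4 in this assay is 30000 nM, between 8000 nM and 100000 nM. For compound 4 the expected step is a step that the limit leaves unreadable from compound 3 to compound 4, nothing beyond scatter. It is expected that compound 4 will most likely again be reported only as a limit.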

Compound 4, half-maximal inhibitory concentration: 5200 nM
Beside the measured number, compound 4's estimate is 5.8-fold (0.76 log units) above it, outside the stated range (below it).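

In this assay, among the compounds shown here, the replacement of hydroxycarbamoyl by (hydroxycarbamoyl)methyl on a saturated chain carbon, four bonds along the chain from two aromatic carbons, gives a readable result for the first time, an at least 3.8-fold lower number from compound 3 to compound 4 (0.58 log units; beyond the scatter), whereas the steps among the three earlier compounds cannot be read. The gain also holds against the other two limit compounds, with an at least 3.8-fold lower number from compound 2 to compound 4 (0.58 log units; beyond the scatter) and an at least 3.8-fold lower number from compound 1 to compound 4 (0.58 log units; beyond the scatter), but compound 1 goes against any simple rule that a longer chain lowers the number, since it carries a methyl on its hydroxamic nitrogen and stays at the limit. Compound 4 is thus the only one of the set that gives a number rather than a limit: the limit of > 20000 nM in this assay, at which 3 of the 4 values shown sit.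

The compounds shown leave open whether the methyl or the chain length keeps compound 1 at the limit, which a longer chain ending in unmethylated hydroxycarbamoyl could separate. They also leave open whether a carboxylic acid in place of the hydroxycarbamoyl end would keep the number of compound 4.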